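This account rests on a few compounds, and the source may have more. Where it says the series, first, only, none or still open, it means among the compounds named here.

Compound 1 `CCOC(=O)CCO/N=C(/c1ccc(OC)c(OC)c1OC)c1cccc2ccccc12` gives 19600 nM in a functional assay on A549 cells (Homo sapiens) for inhibition, read by sulforhodamine B assay, with a stated time of 48 h; a higher number here means a weaker inhibitor, a lower number a stronger inhibitor; compound 2 `COc1ccc(C(c2ccc(OC(C)CN(C)C)cc2)c2cccc3ccccc23)c(OC)c1OC` gives 11400 nM; compound 3 `CCOC(=O)/C=C/CO/N=C(/c1ccc(OC)c(OC)c1OC)c1cccc2ccccc12` gives 14000 nM.

Compound 2 sits within the usual scatter of both compound 3 and compound 1, so the three numbers cannot be ordered. Compound 4 `COc1ccc(C(c2ccc(OCC(=O)O)cc2)c2cccc3ccccc23)c(OC)c1OC` differs from compound 2 by carboxymethyl in place of 1-((dimethylamino)methyl)ethyl on an oxygen on an aromatic ring. For the measured compounds named here, the only measured step, a 1.4-fold lower number from compound 1 to compound 3 (0.15 log units; within the scatter), alters a different side chain in the oxime series and stayed within the scatter, so it says little about exchanging an amine-bearing chain for a carboxymethyl group. Going by the values given here, with no step bearing on this change, the number for compound 4 is expected near that of compound 2, with a wide range, as a 1.8-fold higher number from compound 2 to compound 4 (0.24 log units; within the scatter). Compound 4 is therefore estimated at 20000 nM, between 6000 nM and 70000 nM.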

Compound 4, half-maximal inhibitory concentration: 16400 nM
Beside the measured number, compound 4's estimate is 1.2-fold (0.09 log units) above it; the range from low to high includes it.
By their numbers in this assay, from the lowest: compounds 2, 3, 4 and 1 (each within the scatter of the next).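

In this assay, carboxymethyl in place of 1-((dimethylamino)methyl)ethyl on an oxygen on an aromatic ring gives a 1.4-fold higher number from compound 2 to compound 4 (0.16 log units; within the scatter). For the compounds shown here, this is the first step at this position, and it shows that these two chains, one bearing an amine and the other a carboxylic acid, are not told apart here. Nothing available explains this result.

As far as these compounds go, whether a longer chain, an amide or an ester on this oxygen would give a step beyond the scatter remains open.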